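The source may hold more compounds than are shown below. What is called first, only, known or untested is meant among the compounds shown, and "the series" means these compounds.

Measured so far in a functional assay on HeLa cells (Homo sapiens) for inhibition, read by CCK-8 assay, with a stated time of 48 h; on this read-out lower numbers stand for stronger inhibition and higher numbers for weaker inhibition:
- compound 1 `COc1ccc(C2=NN(C3=NC(c4ccccc4)CS3)C(c3cccc4ccccc34)C2)cc1` gives 3310 nM
- compound 2 `O=C1CSC(N2N=C(c3ccc(Br)cc3)CC2c2ccc3ccccc3c2)=N1` gives 4220 nM
- compound 3 `Brc1ccc(C2=NN(C3=NC(c4ccccc4)CS3)C(c3ccc4ccccc4c3)C2)cc1` gives 4960 nM

Compound 2 at 4220 nM lies within the scatter of both compound 1 and compound 3, so the three values form one group. Compound 4 `Cc1ccc(C2=NN(C3=NC(=O)CS3)C(c3ccc4ccccc4c3)C2)cc1C` differs from compound 2 by 3,4-dimethylphenyl in place of 4-bromophenyl on a carbon with a double bond to nitrogen and carries 3,4-dimethylphenyl in place of 4-bromophenyl on a carbon with a double bond to nitrogen. Going by the values given here, the only measured step is a 1.2-fold higher number from compound 2 to compound 3 (0.07 log units; within the scatter) and it lies elsewhere, on an amine nitrogen in a ring. Among the compounds with values here, no measured step changes this group alone, so the evidence is thin. In this assay no step beyond the scatter is expected. The estimated step is a 1.1-fold lower number from compound 2 to compound 4 (0.02 log units; within the scatter) for this change. Compound 4 is estimated at 4000 nM with an expected range from 1800 nM to 9000 nM for now.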

Compound 4, half-maximal inhibitory concentration: 860 nM
Compound 4: the middle estimate sits 4.7-fold (0.67 log units) above what was measured, outside the stated range (below it).
By their numbers in this assay, from the lowest: compound 4; then compounds 1, 2 and 3 (each within the scatter of the next).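

In this assay this position proves sensitive to the aryl group: 3,4-dimethylphenyl in place of 4-bromophenyl gives a 4.9-fold lower number from compound 2 to compound 4 (0.69 log units; beyond the scatter) and is the only listed step beyond the scatter. The step on the ring nitrogen, a 1.2-fold higher number from compound 2 to compound 3 (0.07 log units; within the scatter), gave no such separation, so the aryl group on the carbon with a double bond to nitrogen is the one place shown to move the number. No measured evidence accounts for this step.

Open, on these data alone, is whether 4-methylphenyl alone would give the same step. Also open, as far as these compounds go, is how a carboxylic acid or an amine on this phenyl ring would read.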